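A few compounds are considered here, and "the series" means these few. Any claim that something is new, unique, unknown or untested is made for them only; others in the source may bear on it.

Working notes on the hydroxamic acid series.

The shared core carries an aryl group on the ring nitrogen, and growth inhibition is followed in a functional assay on MDA-MB-231 cells (Homo sapiens) for inhibition, read by sulforhodamine B assay; on this read-out lower numbers stand for stronger inhibition of growth and higher numbers for weaker inhibition of growth. Compound 1 `CCOc1ccc(CCCN2CC=C(CCC(=O)NO)C2=O)cc1` gives 2210 nM in this assay. Compound 3 `CC(C)(C)c1ccc(CCCN2CC=C(CCC(=O)NO)C2=O)cc1` gives 2210 nM, and the step of no change at the digits printed from compound 1 to compound 3 (within the scatter) shows that exchanging one group for another on that aromatic carbon left the read-out where it was. Compound 2 `Cc1ccc(CN2CC=C(CCC(=O)NO)C2=O)cc1`, with a shorter linker between the aromatic ring and the core, gives 1990 nM in this assay; its number lies alongside those of compound 1 and compound 3, and all three fall together within the usual scatter, so no ordering among them can be drawn.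

Compound 4 `O=C(CCC1=CCN(Cc2ccc(Cl)cc2)C1=O)NO` differs from compound 2 only on the aromatic ring: chloro in place of methyl on an aromatic carbon. Among the measured compounds shown here, no measured pair swaps methyl for chloro. For the measured compounds named here, the only measured step at the same kind of position, from compound 1 to compound 3, was flat, and the three numbers so far show no movement with the aryl substituent. On that basis the step from compound 2 to compound 4 is expected to stay within the scatter, a 1.0-fold higher number from compound 2 to compound 4 (0.00 log units; within the scatter). Compound 4 is therefore estimated at 2000 nM in this assay, with a range from 1000 nM to 4000 nM.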

Compound 4, concentration for 50% growth inhibition: 1990 nM
Compound 4: middle estimate off by 1.0-fold (0.00 log units), on the high side; the range from low to high includes it.
By their numbers in this assay, from the lowest: compounds 2, 4, 1 and 3 (each within the scatter of the next).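

With the shorter linker of compound 2 and compound 4, the step of no change at the digits printed from compound 2 to compound 4 (within the scatter) is a second flat exchange at this position, on an aromatic carbon para to a large group. Chloro in place of methyl leaves the number in this assay where it stood, so the flat reading first seen for tert-butyl in place of ethoxy with the longer linker now also holds for a halogen replacing a small alkyl group with the shorter linker. Nothing available here bears on why either exchange is flat.

All four substituents shown are ethoxy, tert-butyl, methyl or chloro, so an amine, a carboxylic acid or a longer chain at this position remains open, as does the ring with only hydrogen there. The linker also remains open, since compound 1 and compound 3 each differ from compound 2 and compound 4 in both the linker and the ring substituent, and no pair shown separates the two changes.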